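The source may report more compounds than this note shows. Statements on the series, on what has been measured and on what is new or still open speak of the compounds shown alone.

Working notes on the series. In a functional assay on PC-3 cells (Homo sapiens) for cytotoxicity, read by MTT assay, with a stated time of 72 h (on this read-out higher numbers stand for weaker inhibition and lower numbers for stronger inhibition), compound 1 `CN1CCN(c2ccc(NC(=N)c3cc4cn[nH]c4cn3)cc2)CC1` gives 45400 nM and stands as the highest of the two numbers in hand; its nearest neighbour is compound 2 `CN1CCN(c2ccc(NC(=N)c3cc4cnn(C)c4cn3)cc2)CC1`, which in this assay gives 32300 nM. Going by the values given here, the one single-point step available is a 1.4-fold lower number from compound 1 to compound 2 (0.15 log units; within the scatter), so it tells nothing beyond the scatter. Compound 3 `N=C(Nc1ccccc1)c1cc2cn[nH]c2cn1` carries the shared core with a plain phenyl on the amidine nitrogen, but for compound 3 this assay reports only "not determined" (no result reported), so no number is in hand for it.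

Compound 4 `CN1CCN(c2ccc(NC(=N)c3cc4c(-c5ccccc5)n[nH]c4cn3)cc2)CC1` differs from compound 1 by one change: phenyl in place of hydrogen on an aromatic carbon. Among the compounds with values here, no measured step touches this position; the only step in hand, from compound 1 to compound 2, concerns the ring nitrogen and lies within the scatter, so it gives no direction for a change on the neighbouring carbon. With nothing bearing on it, the expectation for compound 4 in this assay is a number close to that of compound 1, with no step beyond the scatter assumed: the estimated step is a 1.6-fold lower number from compound 1 to compound 4 (0.21 log units; within the scatter). Compound 4 is therefore expected to give about 28000 nM in this assay, within a range from 7000 nM to 90000 nM.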

Compound 4, half-maximal inhibitory concentration: 17100 nM
Beside the measured number, compound 4's estimate is 1.6-fold (0.21 log units) above it, within the range that was stated.
By their numbers in this assay, from the lowest: compounds 4, 2 and 1 (each within the scatter of the next, the first and the last beyond it).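

In this assay, going by these compounds alone, phenyl in place of hydrogen on an aromatic carbon of the five-membered aromatic ring gives a 2.7-fold lower number from compound 1 to compound 4 (0.42 log units; beyond the scatter), the first step that lies beyond the scatter. Within the data shown here, the earlier step, a 1.4-fold lower number from compound 1 to compound 2 (0.15 log units; within the scatter), concerned the ring nitrogen and lay within the scatter, so this carbon is the one place so far where a single change moves the number measurably, though the step is modest and points towards stronger inhibition. Nothing measured bears on the reason for this step.

As far as these compounds go, a single group at this carbon cannot show whether the step depends on the aromatic ring itself or on any added bulk, so it remains open whether an amine, a carboxylic acid or a longer alkyl chain at the same place would lower the number further, leave it unchanged or raise it. From the compounds shown here alone, it also remains open whether phenyl at this carbon gives a similar step when the ring nitrogen carries methyl, as in compound 2, or when a plain phenyl sits on the amidine nitrogen, as in compound 3.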